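One aryl group for another on a shared core

The source may hold more compounds than are shown below. What is called first, only, known or untested is meant among the compounds shown, and "the series" means these compounds.

For the measured compounds named here, compound 2 `OC[C@H]1OC(n2cnc3c(-c4ccc(O)cc4)ncnc32)[C@H](O)[C@@H]1O` gives 5000 nM in a functional assay on L1210 cells (Mus musculus) for inhibition (on this read-out higher numbers stand for weaker inhibition and lower numbers for stronger inhibition), the higher of the two numbers so far, though compound 1 `OC[C@H]1OC(n2cnc3c(-c4ccccn4)ncnc32)[C@H](O)[C@@H]1O`, which gives 4300 nM, sits within the scatter of it. Compound 3 `OC[C@H]1OC(n2cnc3c(-c4ccsc4)ncnc32)[C@H](O)[C@@H]1O` differs from compound 2 in one place: thiophen-3-yl in place of 4-hydroxyphenyl on an aromatic carbon. Going by the values given here, the only measured step at this same aromatic carbon, a 1.2-fold higher number from compound 1 to compound 2 (0.07 log units; within the scatter), stayed within the scatter, so the move to compound 3 is expected to give no change at the digits printed from compound 2 to compound 3 (within the scatter), nothing beyond the scatter. Compound 3 is therefore estimated at 5000 nM, with a range from 2000 nM to 12000 nM.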

Compound 3, half-maximal inhibitory concentration: 10800 nM
The estimate for compound 3 lay 2.2-fold (0.33 log units) below the measured number; the measured number falls inside the stated range.
By their numbers in this assay, from the lowest: compounds 1 and 2 (each within the scatter of the next); then compound 3.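

The aromatic carbon does respond to the choice of ring: thiophen-3-yl weakens inhibition in this assay beyond the scatter against both earlier compounds (a 2.2-fold higher number from compound 2 to compound 3 (0.33 log units; beyond the scatter); a 2.5-fold higher number from compound 1 to compound 3 (0.40 log units; beyond the scatter)). For the compounds shown here, the two steps are modest, yet they are the first at this position to pass the scatter. No measurement here accounts for the shift. Going by these compounds alone, whether the smaller ring or its sulfur matters stays open, since only one five-membered ring appears. An amine or a simple methyl group on this carbon would show how far inhibition depends on having an aromatic ring there.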